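This account rests on a few compounds, and the source may have more. Where it says the series, first, only, none or still open, it means among the compounds named here.

Compound 2 `CCCCNc1nc(NCc2ccccc2)c2ccccc2n1` has been examined in a physicochemical assay for solubility, at pH 2; a lower number here means a less soluble compound, a higher number a more soluble compound. In this assay compound 2 gives >= 30000 nM, which is a limit of the assay rather than a number. Its neighbour, compound 1 `CCCCNc1nc(NCCCC)c2ccccc2n1`, carries a propyl where compound 2 carries a phenyl on a saturated chain carbon bound to a nitrogen on the aromatic core. In this assay compound 1 gives >= 30000 nM, again a limit. The step that the two limits leave unreadable from compound 1 to compound 2 is therefore unreadable, since both ends sit at the same boundary, a point summed up by the limit of >= 30000 nM in this assay, at which 2 of the 2 values shown sit.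

Compound 3 `c1ccc(CNc2nc(Nc3ccccc3)nc3ccccc23)cc1` is the next change: phenyl in place of butyl on a nitrogen on an aromatic ring. Going by the values given here, no measured step bears on this change, so only the two limits guide the expectation. The step of a number no higher from compound 2 to compound 3 (the limit leaves the size open) is expected to leave compound 3 close to the boundary seen so far. Compound 3 is estimated at 30000 nM, with a range from 8000 nM to 60000 nM.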

Compound 3, solubility: <= 5000 nM
Compound 3: no number, only a limit; the forecaster's own chance of this, stated with the estimate: 55%; middle value at least 6.0-fold (0.77 log units) away from the limit.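

The only earlier step, made on a saturated chain carbon, could not be read, so the series had not yet shown a clear difference between any two compounds. The change at the nitrogen on the aromatic ring, from butylamino to anilino, gives the first readable result in this assay, with an at least 6.0-fold lower number from compound 2 to compound 3 (0.77 log units; beyond the scatter) as phenyl replaces butyl. Going by these compounds, compound 2 and compound 3 both carry limits rather than numbers, so this step has only a minimum size and its full size stays open: the limit of <= 5000 nM in this assay, at which 1 of the 3 values shown sits.

How far the number falls for compound 3 remains unknown, and the compounds shown give no reason for the change. On these data alone, it is also open whether a chain ending in an amine or a carboxylic acid at this nitrogen would keep the number near that of compound 2 or bring it nearer that of compound 3.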